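Series notes: from compound 3 to compound 4

The compounds below may be only part of what the source reports. "The series", "measured", "known", "first", "only" and "open" are said of these compounds alone.

In an assay on isolated protein for binding affinity to prostaglandin E2 receptor EP4 subtype (Homo sapiens) (a higher number here means a weaker inhibitor, a lower number a stronger inhibitor), compound 1 `O=C(CCc1ccccc1-c1ccccc1CSCCc1ccccc1)NS(=O)(=O)c1cccs1` gives 1500 nM and compound 2 `O=C(CCc1ccccc1-c1cccc(CSCCc2ccccc2)c1)NS(=O)(=O)c1cccs1` gives 1000 nM; these two lie within the usual scatter of each other. Compound 3 `O=C(CCc1ccccc1-c1ccc(OCCCOc2cccc(CSCCc3ccccc3)c2)cc1)NS(=O)(=O)c1cccs1` gives 7100 nM in this assay, the highest number of the three and beyond the scatter from both compound 1 and compound 2, so it is the weakest binder measured so far. Compound 4 `Cc1cccc(OCCCOc2ccc(-c3ccccc3CCC(=O)NS(=O)(=O)c3cccs3)cc2)c1` differs from compound 3 by hydrogen in place of phenethylsulfanyl on a saturated chain carbon bound to an aromatic carbon. For the measured compounds named here, no measured pair shows this change, so its size is not known from the data. A moderate further rise in the inhibition constant is expected, as a 1.7-fold higher number from compound 3 to compound 4 (0.23 log units; within the scatter) states. Compound 4 is expected to give 12000 nM in this assay, with a range of 3000 nM to 50000 nM.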

Compound 4, inhibition constant: 1600 nM
Estimate against measurement, compound 4: 7.5-fold (0.88 log units) above; measured number outside the range, below it.
By their numbers in this assay, from the lowest: compounds 2, 1 and 4 (each within the scatter of the next); then compound 3.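

For the compounds shown here, this is the only single-place step so far: in this assay, cutting (phenethylsulfanyl)methyl back to methyl gives a 4.4-fold lower number from compound 3 to compound 4 (0.65 log units; beyond the scatter), so binding at this position responds to this change. The phenethylsulfanyl, with its 9 heavy atoms and aromatic ring, is not required for the binding seen with compound 4, and here its presence goes with a higher number. No measurement available bears on the reason for this shift. Still open, from the compounds shown here alone, is whether a hydroxyl or an amine on this saturated chain carbon bound to an aromatic carbon, or a shorter thioether chain in place of phenethylsulfanyl, would give a lower number than methyl.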